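Chloro Added to the Most Effective Aryl Urea

The source may report more compounds than this note shows. Statements on the series, on what has been measured and on what is new or still open speak of the compounds shown alone.

Compound 3 `COc1cc2cc(Oc3ccc(NC(=O)Nc4cccc(C(F)(F)F)c4)cc3)c(C)nc2cc1OC` gives the lowest number of three in a functional assay on M14 cells (Homo sapiens) for inhibition, read by sulforhodamine B assay, with a stated time of 48 h, tested at 10 uM; on this read-out higher numbers stand for a weaker effect at the one concentration tested and lower numbers for a stronger effect: compound 3 gives 22.7%, while compound 1 `COc1cc2cc(Oc3ccc(NC(=O)Nc4ccccc4)cc3)c(C)nc2cc1OC` gives 93.7% and compound 2 `COc1cc2cc(Oc3ccc(NC(=O)Nc4ccc(C(F)(F)F)cc4)cc3)c(C)nc2cc1OC` gives 95.2%. Both steps to compound 3 are large, a number 71 percentage points lower from compound 1 to compound 3 (beyond the scatter) and a number 72.5 percentage points lower from compound 2 to compound 3 (beyond the scatter), whereas a number 1.5 percentage points higher from compound 1 to compound 2 (within the scatter). Compound 4 `COc1cc2cc(Oc3ccc(NC(=O)Nc4ccc(Cl)c(C(F)(F)F)c4)cc3)c(C)nc2cc1OC` differs from compound 3 by chloro in place of hydrogen on an aromatic carbon. Going by the values given here, no measured step adds chloro; the measured steps concern only where the trifluoromethyl group sits on this ring, and they show that a change on this ring can move the number far in this assay. Since the trifluoromethyl group is kept, compound 4 is expected to stay near compound 3, with a number 2.3 percentage points higher from compound 3 to compound 4 (within the scatter) expected to lie within the scatter. Compound 4 is therefore estimated at 25%, between 5% and 60%.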

Compound 4, a percentage reported as activity, at one concentration (the size of the read-out at that concentration, not a potency): -73.7%
Estimate against measurement, compound 4: 98.7 percentage points above; measured number below the stated range.
By their numbers in this assay, from the lowest: compound 4; then compound 3; then compounds 1 and 2 (each within the scatter of the next).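

In this assay, going by these compounds alone, chloro on the aromatic carbon ortho to a trifluoromethyl group and para to a large group gives a number 96.4 percentage points lower from compound 3 to compound 4 (beyond the scatter), so this position, unsubstituted in the earlier compounds, can move the number far with a single added atom. Compound 4 also lies far from the two weaker compounds, with a number 168.9 percentage points lower from compound 2 to compound 4 (beyond the scatter) and a number 167.4 percentage points lower from compound 1 to compound 4 (beyond the scatter). No evidence here bears on why the chloro step is so large. As far as these compounds go, it remains open whether fluoro, bromo, methyl or methoxy at this position would do the same, and whether chloro would do so without the trifluoromethyl group.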